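A Fluoro Step at the Limit of the Assay

This account rests on a few compounds, and the source may have more. Where it says the series, first, only, none or still open, it means among the compounds named here.

Compound 1 `O=C(CN1CCCC1)Nc1ccc2ncnc(Nc3ccc(Br)cc3)c2c1` and compound 2 `O=C(CN1CCCC1)Nc1ccc2ncnc(Nc3ccc(OCc4ccccc4)cc3)c2c1` share one core and differ in one place. In a functional assay on MCF7 cells (Homo sapiens) for antiproliferative activity, read by MTT assay, with a stated time of 48 h (a lower number here means a stronger inhibitor, a higher number a weaker inhibitor), compound 1 gives > 100000 nM, which is a limit and not a number. In this assay, compound 2 gives > 100000 nM, also a limit. Going by the values given here, the one measured step is a step that the two limits leave unreadable from compound 1 to compound 2, with benzyloxy in place of bromo, so it offers no size to carry forward. Compound 2 therefore stands at the limit of > 100000 nM in this assay, at which 2 of the 2 values shown sit.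

Compound 3 `O=C(CN1CCCC1)Nc1ccc2ncnc(Nc3ccc(OCc4cccc(F)c4)cc3)c2c1` changes benzyloxy to (3-fluorobenzyl)oxy, with fluoro in place of hydrogen on an aromatic carbon. With no readable step to draw on, no shift beyond the scatter is expected, and the expected step is a number no higher from compound 2 to compound 3 (the limit leaves the size open). For compound 3 the estimated value is 100000 nM, with an expected range from 40000 nM to 200000 nM.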

Compound 3, half-maximal inhibitory concentration: 25000 nM
Estimate against measurement, compound 3: 4.0-fold (0.60 log units) above; measured number below the stated range.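

In this assay, going by these compounds alone, the one value that is not a limit comes with fluoro in place of hydrogen on the aromatic carbon of the benzyloxy group, and the change is an at least 4.0-fold lower number from compound 2 to compound 3 (0.60 log units; beyond the scatter). Set against the bromo of compound 1, the (3-fluorobenzyl)oxy group gives an at least 4.0-fold lower number from compound 1 to compound 3 (0.60 log units; beyond the scatter), so this position can carry a readable value where bromo and benzyloxy gave none. Going by these compounds, both steps start from a limit, so their full size stays open, and only compound 3 has moved off it: the limit of > 100000 nM in this assay, at which 2 of the 3 values shown sit.

On these data alone, whether chloro, methoxy or an amine in place of this fluoro would also give a readable value, or a lower one, stays open. Also open, as far as these compounds go, is whether a second fluoro on the same ring would lower the number further.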